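A few compounds are considered here, and "the series" means these few. Any claim that something is new, unique, unknown or untested is made for them only; others in the source may bear on it.

Measured compounds:
compound 1 `CCOC(=O)C1=C(C)NC(C)=C(C(=O)OCC)C1c1ccc(OCC(=O)NNC(=O)c2sccc2Cl)cc1` — 56.3% in a functional assay on the whole organism (strain Wistar) for inhibition, with Rattus norvegicus as the target, read by paw edema, with stated times of 30 min and 3 h, at a dose of 20 mg/kg; a lower number here means less inhibition, a higher number more inhibition at the dose given (going by the name of the read-out)
compound 2 `CCOC(=O)C1=C(C)NC(C)=C(C(=O)OCC)C1c1ccc(OCC(=O)NNC(=O)c2cccs2)cc1` — 61.1% in this assay

Compound 2 stands highest of these two numbers, but the step of a number 4.8 percentage points higher from compound 1 to compound 2 (within the scatter) lies within the scatter, so the two compounds cannot be told apart. Compound 3 `CCOC(=O)C1=C(C)NC(C)=C(C(=O)OCC)C1c1ccc(OCC(=O)n2nc(C)cc2C)cc1` differs from compound 2 in one place: 3,5-dimethyl-1H-pyrazol-1-yl in place of (((thiophen-2-yl)carbonyl)amino)amino on a carbonyl carbon. Among the compounds with values here, no measured step bears on this kind of change; the only known step, a number 4.8 percentage points higher from compound 1 to compound 2 (within the scatter), concerns another part of the structure and was small. With nothing pointing to a direction, compound 3 is expected to show a step of a number 8.1 percentage points lower from compound 2 to compound 3 (within the scatter), no larger than the scatter. The estimate for compound 3 is therefore 53%, with a range from 35% to 68%.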

Compound 3, a percentage reported as inhibition, in the whole organism at one dose (the size of the read-out at that dose, not a potency): 48.5%
For compound 3 the middle estimate is 4.5 percentage points above the measured one; the measured number falls inside the stated range.
By their numbers in this assay, from the lowest: compounds 3, 1 and 2 (each within the scatter of the next, the first and the last beyond it).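

Within the data shown here, exchanging the (((thiophen-2-yl)carbonyl)amino)amino group on the carbonyl carbon for 3,5-dimethyl-1H-pyrazol-1-yl gives the first step beyond the scatter in this assay, namely a number 12.6 percentage points lower from compound 2 to compound 3 (beyond the scatter), and so this position does respond to a change. Measured against the chlorinated group, the result is a number 7.8 percentage points lower from compound 1 to compound 3 (within the scatter), so the drop is modest and clear against only one of the two. Nothing at hand explains the step. Open remains how a carboxylic acid or a simple amine on this carbonyl carbon would read, and whether the two methyl groups of the pyrazole contribute.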